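Amide-terminus variation on the spiro-piperidine series

A few compounds are considered here, and "the series" means these few. Any claim that something is new, unique, unknown or untested is made for them only; others in the source may bear on it.

Among the measured compounds shown here, compound 2 `CC(C)(C)c1ccc(C(=O)N2CCC3(CC2)C(=O)N(CC(=O)N2CCCC(CO)C2)CN3c2ccccc2)cc1` carries the highest of the two numbers so far in an assay on HEK293 cells for displacement of a labelled ligand from NPC1-like intracellular cholesterol transporter 1 (Homo sapiens) (a lower number here means a stronger inhibitor, a higher number a weaker inhibitor), giving 8200 nM; its only neighbour, compound 1 `CC(C)(C)c1ccc(C(=O)N2CCC3(CC2)C(=O)N(CC(=O)NCCCN)CN3c2ccccc2)cc1`, gives 4200 nM in this assay, and the two lie within the scatter of each other. The step of a 2.0-fold higher number from compound 1 to compound 2 (0.29 log units; within the scatter) shows that exchanging the open-chain (3-aminopropyl)amino terminus for the cyclic 3-(hydroxymethyl)piperidin-1-yl moved the number by no more than the scatter. Compound 3 `CC(C)(C)c1ccc(C(=O)N2CCC3(CC2)C(=O)N(CC(=O)NCCCCNS(C)(=O)=O)CN3c2ccccc2)cc1` now returns to an open chain: (4-(methanesulfonamido)butyl)amino in place of 3-(hydroxymethyl)piperidin-1-yl on a carbonyl carbon. For the measured compounds named here, the one measured step that bears on this position, from compound 1 to compound 2, was small, so no step beyond the scatter is expected here in this assay, with a slight lean toward the number of compound 1. Compound 3 is therefore estimated at 5500 nM, between 2000 nM and 15000 nM, which means an expected step of a 1.5-fold lower number from compound 2 to compound 3 (0.17 log units; within the scatter).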

Compound 3, half-maximal inhibitory concentration: 4500 nM
The estimate for compound 3 lay 1.2-fold (0.09 log units) above the measured number; low and high end bracket the measured number.
By their numbers in this assay, from the lowest: compounds 1, 3 and 2 (each within the scatter of the next).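

In this assay, the new compound gives two readings: a 1.8-fold lower number from compound 2 to compound 3 (0.26 log units; within the scatter) and a 1.1-fold higher number from compound 1 to compound 3 (0.03 log units; within the scatter). This position, on a carbonyl carbon, therefore holds the (3-aminopropyl)amino chain, the cyclic 3-(hydroxymethyl)piperidin-1-yl and the (4-(methanesulfonamido)butyl)amino chain with all three compounds within the scatter of one another, and (methanesulfonamido)methyl in place of amino on the open chain gives no step beyond the scatter. No supporting data are available to explain this result.

Still open, from the compounds shown here alone, is whether any terminus at this position can produce a step beyond the scatter, for instance a carboxylic acid or an aromatic ring at the chain end. A plain 4-aminobutyl chain would separate the added chain length from the methanesulfonyl group, which compound 3 introduces together.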